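A Cyano Group Enters the Ring of Compound 2

The source may hold more compounds than are shown below. What is called first, only, known or untested is meant among the compounds shown, and "the series" means these compounds.

Of the compounds shown here, two have been measured in an assay on membranes from brain for binding affinity to Monoglyceride lipase (Mus musculus), read by fluorescence, with stated times of 1 h and 30 min; a lower number here means a stronger inhibitor, a higher number a weaker inhibitor. Compound 1 `Cc1cnn(C(=O)NCc2ccc(OCc3ccccc3)cc2)c1` gives 1000 nM. Compound 2 `O=C(NCc1ccc(OCc2ccccc2)cc1)n1cccn1` gives 900 nM, the lowest of the two numbers, yet the change a 1.1-fold lower number from compound 1 to compound 2 (0.05 log units; within the scatter) shows the two lie within the scatter of each other, so neither can be called the stronger. Compound 3 `N#Cc1cnn(C(=O)NCc2ccc(OCc3ccccc3)cc2)c1` has not been measured; it differs from compound 2 by cyano in place of hydrogen on an aromatic carbon. Among the measured compounds shown here, the single measured step exchanged methyl for hydrogen at the same ring carbon and moved the number only within the scatter, so that carbon has so far tolerated a small change without effect. For the measured compounds named here, no measured step introduces a cyano group, so little can be said with confidence. The step of a 1.3-fold lower number from compound 2 to compound 3 (0.11 log units; within the scatter) is therefore expected to stay small, with a wide range. Compound 3 is estimated at 700 nM, between 200 nM and 2500 nM.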

Compound 3, half-maximal inhibitory concentration: 100 nM
Compound 3: the middle estimate sits 7.0-fold (0.85 log units) above what was measured; the measured number lies below the stated range.
By their numbers in this assay, from the lowest: compound 3; then compounds 2 and 1 (each within the scatter of the next).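

Exchanging methyl for hydrogen on this ring carbon gave no readable change, so the position looked indifferent to what it carries, but in this assay cyano in place of hydrogen brings a 9.0-fold lower number from compound 2 to compound 3 (0.95 log units; beyond the scatter) and shows that the position can matter. Cyano in place of methyl at the same carbon brings a 10-fold lower number from compound 1 to compound 3 (1.00 log units; beyond the scatter) in this assay and so sets compound 3 apart from both earlier compounds, not just from one of them. Nothing available explains why cyano behaves differently here from hydrogen and methyl.

The compounds shown leave open whether this gain is particular to cyano or would also come with another group on the same carbon, such as a chlorine atom, a carboxylic acid or a methyl ester. They also leave open whether cyano on a different carbon of the five-membered aromatic ring would give a similar step.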